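Series notes: a 3-nitrophenyl analogue of compound 1

The source may report more compounds than this note shows. Statements on the series, on what has been measured and on what is new or still open speak of the compounds shown alone.

Measured in a functional assay on MCF7 cells (Homo sapiens) for inhibition, read by MTT assay, with a stated time of 48 h; a lower number here means a stronger inhibitor, a higher number a weaker inhibitor:
- compound 1 `Fc1ccccc1CSc1nnc(-c2ccncc2)n1-c1ccccc1` gives > 50000 nM, a limit of the assay.
- compound 2 `Clc1ccc(CSc2nnc(-c3ccncc3)n2-c2ccccc2)cc1` gives 13300 nM.
- compound 3 `O=[N+]([O-])c1ccccc1CSc1nnc(-c2ccncc2)n1-c1ccccc1` gives > 50000 nM, a limit of the assay.

Compound 1 stands only at a limit in this assay, and compound 3 sits at the same limit (the limit of > 50000 nM in this assay, at which 2 of the 3 values shown sit). The change to compound 4 `O=[N+]([O-])c1cccc(CSc2nnc(-c3ccncc3)n2-c2ccccc2)c1` is 3-nitrophenyl in place of 2-fluorophenyl on a saturated chain carbon bound to a sulfur. The measured steps that bear on it: a step that the two limits leave unreadable from compound 1 to compound 3, which the two limits leave unreadable, and an at least 3.7-fold higher number from compound 2 to compound 3 (0.57 log units; beyond the scatter), at least modest. Only compound 2 gives a number; the nitro analogue compound 3 stays at the limit. For compound 4 the expectation is again no readable activity or at best a weak one, so the step is estimated as a number no higher from compound 1 to compound 4 (the limit leaves the size open). Compound 4 is estimated at 50000 nM, range 15000 nM to 150000 nM.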

Compound 4, half-maximal inhibitory concentration: 18300 nM
Beside the measured number, compound 4's estimate is 2.7-fold (0.44 log units) above it, within the range that was stated.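

Compound 1 and compound 3 stand only at a limit of the assay: the limit of > 50000 nM in this assay, at which 2 of the 4 values shown sit.

In this assay, 3-nitrophenyl gives a readable value, with an at least 2.7-fold lower number from compound 1 to compound 4 (0.43 log units; beyond the scatter) and an at least 2.7-fold lower number from compound 3 to compound 4 (0.43 log units; beyond the scatter), so 3-nitrophenyl and 2-nitrophenyl are not interchangeable on this saturated chain carbon. Against 4-chlorophenyl the step is a 1.4-fold higher number from compound 2 to compound 4 (0.14 log units; within the scatter), so these two groups cannot be ranked.

Open, as far as these compounds go, is whether 4-nitrophenyl, or a phenyl carrying an amine or a carboxylic acid, would keep this level of inhibition. Also open, from the compounds shown here alone, is what a longer chain on the sulfur would do.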